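Notes on compound 1 and its amino analogue compound 4

The compounds below may be only part of what the source reports. "The series", "measured", "known", "first", "only" and "open" are said of these compounds alone.

Measured compounds and values:
compound 1 `CCn1cc(-c2nc3ccccc3[nH]2)c(=O)c2cc(F)c(N3CCNCC3)cc21` gives 27400 nM
compound 2 `CCn1cc(-c2nc3ccccc3[nH]2)c(=O)c2cc(F)c(N3CCNC(C)C3)c(F)c21` gives 30200 nM
compound 3 `CCn1cc(-c2nc3ccc([N+](=O)[O-])cc3s2)c(=O)c2cc(F)c(N3CCNCC3)nc21` gives 24600 nM

All three numbers come from a functional assay on Bel-7402 cells (Homo sapiens) for cytotoxicity, read by MTT assay, with a stated time of 48 h; on this read-out higher numbers stand for weaker inhibition and lower numbers for stronger inhibition. Compound 1 stands second highest of the three. Its nearest neighbour is compound 2, whose number lies within the scatter of it, and compound 3, the furthest, is likewise within the scatter. The three measured compounds therefore cannot be ordered on this read-out; all three sit in the same weak band, and nothing in them points to one change that moves the number.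

Compound 4 `CCn1cc(-c2nc3ccc(N)cc3[nH]2)c(=O)c2cc(F)c(N3CCNCC3)cc21` has not yet been measured in this assay. Relative to compound 1 it shows one change: amino in place of hydrogen on an aromatic carbon. Among the compounds with values here, no measured pair in the set carries this change, so its effect here cannot be read from the data; the expectation for it rests only on the flat picture given by compound 1, compound 2 and compound 3.

The expected step of a 1.1-fold lower number from compound 1 to compound 4 (0.04 log units; within the scatter) is taken as none beyond the scatter, in neither direction. Within the data shown here, compound 4 is accordingly estimated at 25000 nM in this assay, with a range from 8000 nM to 70000 nM; the true number could fall outside this range if the amino group matters more than the series so far suggests.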

Compound 4, half-maximal inhibitory concentration: 92100 nM
Estimate against measurement, compound 4: 3.7-fold (0.57 log units) below; the whole stated range lies below it.
By their numbers in this assay, from the lowest: compounds 3, 1 and 2 (each within the scatter of the next); then compound 4.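

In this assay, the aromatic carbon that is meta to a fused ring and para to a fused ring in compound 1 is not a silent place: amino in place of hydrogen gives a 3.4-fold higher number from compound 1 to compound 4 (0.53 log units; beyond the scatter), a modest step toward weaker inhibition. Within the data shown here, the earlier compounds differ from one another in more than one place and offer no single-change step, so their flat picture said nothing about this carbon; this pair is the first one-place comparison, and the change moves the number beyond the scatter. No measurement at hand explains the step, so the reason for it remains unknown.

As far as these compounds go, what stays open is whether this step belongs to amino specifically or would follow any replacement of hydrogen on this carbon, a question that a chlorine atom, a methoxy group or an acetamide at the same place could address. From the compounds shown here alone, it is also open whether the step carries over to other backgrounds, since it rests on one pair, and amino on the core of compound 2 would test that directly.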